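The source may hold more compounds than are shown below. What is called first, only, known or untested is meant among the compounds shown, and "the series" means these compounds.

The measured compounds in a functional assay on MCF7 cells (Homo sapiens) for inhibition; on this read-out lower numbers stand for stronger inhibition and higher numbers for weaker inhibition:
Compound 1 `CC/C(=C(/c1ccc(/C=C/C(=O)O)cc1)c1cc2ccccc2[nH]1)c1ccccc1C`, which gives 33 nM
Compound 2 `CC/C(=C(/c1ccc(/C=C/C(=O)O)cc1)c1cc2ccccc2[nH]1)c1ccc(Cl)cc1`, which gives 343 nM
Compound 3 `CC/C(=C(/c1ccc(/C=C/C(=O)O)cc1)c1cc2ccccc2[nH]1)c1cccc(Cl)c1Cl`, which gives 898 nM

Compound 3 stands highest of the three, with a 2.6-fold higher number from compound 2 to compound 3 (0.42 log units; beyond the scatter) and a 27-fold higher number from compound 1 to compound 3 (1.43 log units; beyond the scatter). Compound 4 `CC/C(=C(/c1ccc(/C=C/C(=O)O)cc1)c1cc2ccccc2[nH]1)c1ccc(C#N)cc1Cl` differs from it in one place: 2-chloro-4-cyanophenyl in place of 2,3-dichlorophenyl on a double-bonded chain carbon bound to a double-bonded chain carbon and a saturated chain carbon. Among the measured compounds shown here, no measured step swaps a chlorine for a nitrile on this phenyl; the steps that bear on it are a 10-fold higher number from compound 1 to compound 2 (1.02 log units; beyond the scatter) and a 27-fold higher number from compound 1 to compound 3 (1.43 log units; beyond the scatter), both large, and a 2.6-fold higher number from compound 2 to compound 3 (0.42 log units; beyond the scatter), modest, and every chlorine-bearing phenyl here sits among the higher numbers. Since compound 4 keeps one chlorine on that phenyl, the step expected in this assay is a 1.0-fold higher number from compound 3 to compound 4 (0.00 log units; within the scatter), not clearly beyond the scatter in either direction. Compound 4 is therefore estimated at 900 nM, within 300 nM to 2700 nM.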

Compound 4, half-maximal inhibitory concentration: 49 nM
Compound 4: middle estimate off by 18-fold (1.26 log units), on the high side; measured number below the stated range.
By their numbers in this assay, from the lowest: compounds 1 and 4 (each within the scatter of the next); then compound 2; then compound 3.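

In this assay, the 2-chloro-4-cyanophenyl group gives an 18-fold lower number from compound 3 to compound 4 (1.26 log units; beyond the scatter) and a 7.0-fold lower number from compound 2 to compound 4 (0.85 log units; beyond the scatter), so on this double-bonded chain carbon a chlorine-bearing phenyl no longer goes only with the higher numbers. The remaining step, a 1.5-fold higher number from compound 1 to compound 4 (0.17 log units; within the scatter), leaves compound 4 level with the 2-methylphenyl of compound 1. Nothing available here accounts for this change. The compounds shown leave open whether the nitrile alone carries the difference from compound 3, and whether a trifluoromethyl group or an amine in its place would keep the number as low.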